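This account rests on a few compounds, and the source may have more. Where it says the series, first, only, none or still open, it means among the compounds named here.

Measured compounds in an assay on CHO cells for displacement of a labelled ligand from adenosine receptor A3 (Homo sapiens), read by scintillation counting, with a stated time of 45 min, tested at 1 uM, in the presence of a further agent that is not named here; a higher number here means more inhibition at the concentration tested (going by the name of the read-out), a lower number less inhibition:
compound 1 `CCCn1c(=O)[nH]c2nc(-c3ccc(S(=O)(=O)N4CCN(c5cccc(Br)c5)CC4)cc3)[nH]c2c1=O` gives 27%
compound 2 `CCCn1c(=O)[nH]c2nc(-c3ccc(S(=O)(=O)N4CCN(C)CC4)cc3)[nH]c2c1=O` gives 7%
compound 3 `CCCn1c(=O)[nH]c2nc(-c3ccc(S(=O)(=O)N4CCN(Cc5ccc(Br)cc5)CC4)cc3)[nH]c2c1=O` gives 28%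

Compound 3 holds the highest of the three numbers in this assay, yet its number stands within the scatter of that of compound 1, and it is set apart only from compound 2, by a number 21 percentage points higher from compound 2 to compound 3 (beyond the scatter). The step of a number 1 percentage points higher from compound 1 to compound 3 (within the scatter) shows that swapping one large group for another on the ring nitrogen left the read-out unchanged, whereas a number 20 percentage points lower from compound 1 to compound 2 (beyond the scatter) shows the fall when the small methyl group sits there.

Compound 4 `CCCn1c(=O)[nH]c2nc(-c3ccc(S(=O)(=O)N4CCN(c5ccccc5C)CC4)cc3)[nH]c2c1=O` carries 2-methylphenyl in place of 4-bromobenzyl on an amine nitrogen in a ring. Going by the values given here, the steps that bear on this are a number 1 percentage points higher from compound 1 to compound 3 (within the scatter), which stayed within the scatter when one large group replaced another on this nitrogen, and a number 21 percentage points higher from compound 2 to compound 3 (beyond the scatter), where a large group in place of hydrogen raised the number. Compound 4 keeps a large group at this place, as compound 1 and compound 3 do, and compound 1 already shows an aromatic ring attached directly to that nitrogen holding the number up. Among the compounds with values here, no measured pair covers the methyl on the entering ring itself. The step is therefore expected to remain within the scatter, a number 4 percentage points lower from compound 3 to compound 4 (within the scatter). Compound 4 is estimated at 24%, with a range from 8% to 40%.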

Compound 4, a percentage reported as inhibition, at one concentration (the size of the read-out at that concentration, not a potency): 25%
The estimate for compound 4 lay 1 percentage points below the measured number; the range from low to high includes it.
By their numbers in this assay, from the lowest: compound 2; then compounds 4, 1 and 3 (each within the scatter of the next).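

In this assay, 2-methylphenyl on the amine nitrogen in the ring cannot be told apart from either group carrying bromine (a number 3 percentage points lower from compound 3 to compound 4 (within the scatter); a number 2 percentage points lower from compound 1 to compound 4 (within the scatter)). The enters group holds no bromine, so among these compounds bromine is not required for a number at this level, and a methyl on the aromatic ring is accepted at this place without a change beyond the scatter. The separation from the small methyl group on this nitrogen now holds for a third large group (a number 18 percentage points higher from compound 2 to compound 4 (beyond the scatter)), with compound 1, compound 3 and compound 4 all on one side and compound 2 alone on the other, though no measurement at hand gives a reason for this.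

A read-out at one concentration shows only the size of the effect at that concentration and cannot show how compound 1, compound 3 and compound 4 would compare at any other, and the separate effects of the methyl and of its place on the aromatic ring remain unresolved. From the compounds shown here alone, it also stays open how this assay would respond to a carboxylic acid or an amine on that aromatic ring, or to a longer chain linking it to the ring nitrogen.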